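Benzyloxy in Place of Methoxy on a Single-Concentration Series

The source may report more compounds than this note shows. Statements on the series, on what has been measured and on what is new or still open speak of the compounds shown alone.

Measured so far:
compound 1, `COc1ccc2c(c1)c(-c1cc(C(F)(F)F)ccn1)cn2S(=O)(=O)c1ccc(C)cc1`, 23.2%
compound 2, `COc1ccc2c(c1)c(-c1cc(C(F)(F)F)cc(-c3cn(S(=O)(=O)c4ccc(C)cc4)c4ccc(OC)cc34)n1)cn2S(=O)(=O)c1ccc(C)cc1`, 7.1%
compound 3, `Cc1ccc(S(=O)(=O)n2cc(-c3cc(C(F)(F)F)cc(-c4cn(S(=O)(=O)c5ccc(C)cc5)c5cc(Br)ccc45)n3)c3ccc(Br)cc32)cc1`, 30.7%

All three were tested in a functional assay on A549 cells (Homo sapiens) for inhibition, tested at 1 uM; on this read-out lower numbers stand for a weaker effect and higher numbers for a stronger effect at the one concentration tested. Compound 1 stands second highest of the three numbers. Its nearest neighbour is compound 3, whose number is higher by an amount within the usual scatter, so the two cannot be told apart on this read-out. Compound 2 lies furthest from compound 1, with a number lower by a gap beyond the scatter; it is the only one of the three that falls clearly below compound 1. Among the measured compounds shown here, compounds 2 and 3 carry two copies of the shared core of compound 1 and differ from it in more than one place, so no single step between measured compounds can be drawn.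

Compound 4, `Cc1ccc(S(=O)(=O)n2cc(-c3cc(C(F)(F)F)ccn3)c3cc(OCc4ccccc4)ccc32)cc1`, is not yet measured. It differs from compound 1 in one place: phenyl in place of hydrogen on a saturated chain carbon bound to an oxygen on an aromatic ring. For the measured compounds named here, since no step of this kind is among the measured compounds, the expectation rests on compound 1 alone. The change from compound 1 to compound 4 is expected to be small, within the scatter, with no clear direction, as a number 1.8 percentage points higher from compound 1 to compound 4 (within the scatter). Compound 4 is therefore estimated at 25%, within a range of 5% to 50%.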

Compound 4, a percentage reported as inhibition, at one concentration (the size of the read-out at that concentration, not a potency): 23.2%
Beside the measured number, compound 4's estimate is 1.8 percentage points above it; low and high end bracket the measured number.
By their numbers in this assay, from the lowest: compound 2; then compounds 1, 4 and 3 (each within the scatter of the next).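

In this assay, the exchange of methoxy for benzyloxy gives no change at the digits printed from compound 1 to compound 4 (within the scatter), so a phenyl on the saturated chain carbon bound to the oxygen on the aromatic ring leaves the read-out without a detectable change. Among the compounds shown here, this is the first single-place comparison: compounds 2 and 3 carry two copies of the shared core and differ from compound 1 in more than one place, so they could say nothing about this position taken alone. Nothing available bears on why the number stays where it does, and no explanation is offered for it.

The compounds shown leave open whether a different group on the same chain carbon, such as an amine, a carboxylic acid or a longer alkyl chain in place of the phenyl, would also leave the number unmoved. They also leave open whether benzyloxy would give the same result on the two-copy scaffold of compound 2, and whether the match seen at this one concentration would hold at other concentrations.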